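The source may report more compounds than this note shows. Statements on the series, on what has been measured and on what is new or still open speak of the compounds shown alone.

In an ADME assay on BJ cells (Homo sapiens) for cytotoxicity, with a stated time of 72 h (a higher number here means that more compound is needed for the effect, a lower number that less compound is needed), compound 1, `CCc1ccc(-c2nc3c(c(C)nn3-c3ccccc3)c(-c3ccccc3O)c2C#N)cc1`, gives > 20000 nM, which is a limit of the assay rather than a number. Compound 2, `CCc1ccc(-c2nc3c(c(C)nn3-c3ccccc3)c(-c3ccccc3[N+](=O)[O-])c2C#N)cc1`, gives > 20000 nM in this assay, again a limit. Compound 3, `CCc1ccc(-c2nc3c(c(C)nn3-c3ccccc3)c(-c3ccccc3Br)c2C#N)cc1`, stands in this assay at > 20000 nM, also a limit. Where compound 3 stands can thus be said only this far: all three measured values sit at the same limit, as the limit of > 20000 nM in this assay, at which 3 of the 3 values shown sit, records. The steps a step that the two limits leave unreadable from compound 1 to compound 2, a step that the two limits leave unreadable from compound 1 to compound 3 and a step that the two limits leave unreadable from compound 2 to compound 3 accordingly have no readable size.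

Compound 4, `CCc1ccc(-c2nc3c(c(C)nn3-c3ccccc3)c(-c3ccccc3C(=O)O)c2C#N)cc1`, differs from compound 3 by carboxy in place of bromo on an aromatic carbon. Among the measured compounds shown here, the steps that bear on this change are those among compounds 1, 2 and 3, and none of them can be read in this assay. No step beyond the scatter is therefore expected in this assay, and the step that the limit leaves unreadable from compound 3 to compound 4 is estimated to be small. Compound 4 is expected to give 40000 nM in this assay, most likely again as a limit, with a range from 15000 nM to 200000 nM.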

Compound 4, half-maximal effective concentration: > 20000 nM
Compound 4 ended at the assay's limit (the forecaster's own chance of this, stated with the estimate: 90%); the middle value is on the limit's open side.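

Compound 4 gives > 20000 nM in this assay, again a limit of the assay, so its steps from compound 1, compound 2 and compound 3 cannot be read: the limit of > 20000 nM in this assay, at which 4 of the 4 values shown sit.

The compounds shown leave open whether hydroxy, nitro, bromo and carboxy differ at all in this assay.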